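The source may hold more compounds than are shown below. What is called first, only, known or untested is meant among the compounds shown, and "the series" means these compounds.

Three ureas built on the same core have been run in an ADME assay on the whole organism (Rattus norvegicus, strain Sprague-Dawley) for pharmacokinetics, read by LC-MS, with a stated time of 24 h; a lower number here means that a smaller share of the oral dose reaches the circulation, a higher number that a larger share of the oral dose reaches the circulation. Compound 1 `CN(C)c1ccc2c(Oc3ccc(NC(=O)NCc4ccc(F)cc4)cc3)ncnc2c1` gives 7.3%. Compound 2 `COc1ccc(CNC(=O)Nc2ccc(Oc3ncnc4cc(N(C)C)ccc34)cc2)cc1` gives 1.6%, and the step of a number 5.7 percentage points lower from compound 1 to compound 2 (within the scatter). Compound 3 `COc1ccc(CNC(=O)Nc2ccc(Oc3ncnc4cc(N(C)C)ccc34)cc2)cn1` gives 30.7% and stands highest of the three numbers; its nearest neighbour is compound 1, with the step of a number 23.4 percentage points higher from compound 1 to compound 3 (beyond the scatter), and its furthest is compound 2, with the step of a number 29.1 percentage points higher from compound 2 to compound 3 (beyond the scatter).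

Compound 4 `COc1ccc(NC(=O)Nc2ccc(Oc3ncnc4cc(N(C)C)ccc34)cc2)cc1` has not yet been measured in this assay. It differs from compound 3 in one place: 4-methoxyphenyl in place of (6-methoxypyridin-3-yl)methyl on an amide-type nitrogen. The two measured steps that bear on this change are those that led into compound 3, namely a number 23.4 percentage points higher from compound 1 to compound 3 (beyond the scatter) and a number 29.1 percentage points higher from compound 2 to compound 3 (beyond the scatter); both were beyond the scatter and both ran toward the (6-methoxypyridin-3-yl)methyl group that compound 4 now gives up. Because a number 29.1 percentage points higher from compound 2 to compound 3 (beyond the scatter) was the larger of these, the removal of that group is expected to cost compound 4 a modest share of what compound 3 reached, though compound 4 carries no measured partner of its own in this assay.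

For compound 4 the expected step reads a number 22.7 percentage points lower from compound 3 to compound 4 (beyond the scatter). Compound 4 is therefore estimated to give 8%, within a range from 1% to 25%.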

Compound 4, oral bioavailability: 3.2%
Beside the measured number, compound 4's estimate is 4.8 percentage points above it; low and high end bracket the measured number.
By their numbers in this assay, from the lowest: compounds 2, 4 and 1 (each within the scatter of the next); then compound 3.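

In this assay the change on the amide-type nitrogen from (6-methoxypyridin-3-yl)methyl to 4-methoxyphenyl gives up the earlier gain (a number 27.5 percentage points lower from compound 3 to compound 4 (beyond the scatter)), so the high number of compound 3 does not survive this swap. The comparisons with the carbon-only benzyl ureas show no readable difference, whether 4-methoxyphenyl replaces 4-methoxybenzyl (a number 1.6 percentage points higher from compound 2 to compound 4 (within the scatter)) or 4-fluorobenzyl (a number 4.1 percentage points lower from compound 1 to compound 4 (within the scatter)), so on this nitrogen a phenyl and these benzyl groups cannot be told apart in this read-out. Among the four compounds, only compound 3, the one whose ring holds a hetero atom, stands apart, and none of the four goes against this.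

Nothing measured here gives a reason for the step. Still open, from the compounds shown here alone, is whether the ring nitrogen alone carries the gain or needs the saturated chain carbon with it, a question that a 6-methoxypyridin-3-yl group set on the amide-type nitrogen without that carbon, or a pyrimidine ring in place of the pyridine, would bear on.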